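The source may report more compounds than this note shows. Statements on the series, on what has been measured and on what is new or still open speak of the compounds shown alone.

In a functional assay on L1210 cells (Mus musculus) for inhibition, read by cell counting, with a stated time of 48 h (a lower number here means a stronger inhibitor, a higher number a weaker inhibitor), compound 1 (`COc1ccc(N(C)c2nc(C)nc3c2nc(C)n3C)cc1`) gives 19000 nM. Compound 2 (`COc1ccc(Nc2nc(C)nc3c2nc(C)n3C)cc1`) stands at >= 250000 nM, which is a limit and not a number. Compound 3 (`CCN(c1ccc(OC)cc1)c1nc(C)nc2c1nc(C)n2C`) differs from compound 2 by ethyl in place of hydrogen on a nitrogen on an aromatic ring. Going by the values given here, the one measured step that bears on this change is an at least 13-fold higher number from compound 1 to compound 2 (1.11 log units; beyond the scatter), large and beyond the scatter, with hydrogen replacing methyl on the same nitrogen. Run in reverse, that step points to a large expected fall in this assay on adding ethyl, though ethyl itself is untested there. The expected change is an at least 11-fold lower number from compound 2 to compound 3 (1.05 log units; beyond the scatter). Compound 3 is estimated at 22000 nM, with an expected range of 7000 nM to 70000 nM.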

Compound 3, half-maximal inhibitory concentration: 35000 nM
Beside the measured number, compound 3's estimate is 1.6-fold (0.20 log units) below it, within the range that was stated.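

Ethyl on this nitrogen repeats what methyl showed, now with a second group: an at least 7.1-fold lower number from compound 2 to compound 3 (0.85 log units; beyond the scatter). Compound 2 is held at a limit and not a number, so that step has only a bound: the limit of >= 250000 nM in this assay, at which 1 of the 3 values shown sits. Methyl and ethyl are not separated here in this assay, with a 1.8-fold higher number from compound 1 to compound 3 (0.27 log units; within the scatter).

The compounds shown do not tell whether a longer chain such as propyl or butyl on this nitrogen would hold the number in this assay. As far as these compounds go, whether a chain ending in an amine or a carboxylic acid would be tolerated there also stays open.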